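The source may report more compounds than this note shows. Statements on the series, on what has been measured and on what is new or still open speak of the compounds shown alone.

Compound 1 `Cc1ccc(NC(=O)Nc2nc(-c3cc4ccccc4o3)cs2)cc1` heads the series in a physicochemical assay, with a stated time of 6 min (on this read-out lower numbers stand for stronger inhibition and higher numbers for weaker inhibition), where compound 1 gives 500 nM, the lowest of the two numbers shown. Compound 2 `COc1ccc(NC(=O)Nc2nc(-c3cc4cc([N+](=O)[O-])ccc4o3)cs2)cc1` differs from compound 1 in two places; in this assay compound 2 gives 121000 nM. Compound 3 `COc1ccc(NC(=O)Nc2nc(-c3cc4cc(Br)ccc4o3)cs2)cc1` reaches only a limit of this assay, > 200000 nM, (the limit of > 200000 nM in this assay, at which 1 of the 3 values shown sits). Among the measured compounds shown here, the single measured step, an at least 1.6-fold higher number from compound 2 to compound 3 (0.21 log units; that floor lies within the scatter), concerns a substituent on an aromatic carbon of the shared core, not the group on the amide-type nitrogen, so no measured step bears on the change to compound 4 `O=C(Nc1cccc(Cl)c1)Nc1nc(-c2cc3ccccc3o2)cs1`, (3-chlorophenyl in place of 4-methylphenyl on an amide-type nitrogen). The values of compounds 2 and 3 cannot be apportioned to either of their two changes. The step of a 1.6-fold higher number from compound 1 to compound 4 (0.20 log units; within the scatter) is therefore expected to stay within the scatter. Compound 4 is expected at 800 nM, between 200 nM and 4000 nM.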

Compound 4, half-maximal inhibitory concentration: 14100 nM
Compound 4: middle estimate off by 18-fold (1.25 log units), on the low side; the measured number lies above the stated range.
By their numbers in this assay, from the lowest: compound 1; then compound 4; then compound 2. At a limit, above all of these: compound 3.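

At the amide-type nitrogen the aryl group clearly counts in this assay: 3-chlorophenyl in place of 4-methylphenyl gives a 28-fold higher number from compound 1 to compound 4 (1.45 log units; beyond the scatter). Among the compounds shown here, this is the first measured step at this position, and the two groups match in heavy atom count, ring type, hydrogen-bond donors and acceptors, and charge. Nothing measured here explains the step.

From the compounds shown here alone, the change swaps the substituent and its ring position together, so the contribution of each stays open. Also open, going by these compounds, is how an amine or a carboxylic acid on this phenyl ring would read.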